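A Small Halogen Replaces a Difluorophenyl Group

The compounds below may be only part of what the source reports. "The series", "measured", "known", "first", "only" and "open" are said of these compounds alone.

Three compounds built on a shared core have been examined in an assay on CHO cells for displacement of a labelled ligand from adenosine receptor A1 (Homo sapiens), read by scintillation counting, tested at 10 uM; on this read-out lower numbers stand for less inhibition and higher numbers for more inhibition at the one concentration tested (going by the name of the read-out). Compound 1 `Cc1sc(N)c(C(=O)c2ccc(Cl)cc2)c1-c1ccccc1` gives 1% in this assay. Compound 2 `CC(C)(C)Cc1csc(N)c1C(=O)c1cccc(Cl)c1` gives 2%. Compound 3 `CC(C)(C)Cc1c(-c2cc(F)ccc2F)sc(N)c1C(=O)c1ccc(Cl)cc1` gives 3%, the highest of the three numbers, yet its gaps to compound 2 and to compound 1 both lie within the usual scatter, so the three compounds read as one flat set rather than a ranking. No change between measured compounds that differs in a single place is available to size any step.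

Compound 4 `CC(C)(C)Cc1c(Br)sc(N)c1C(=O)c1ccc(Cl)cc1` differs from compound 3 in one place: bromo in place of 2,5-difluorophenyl on an aromatic carbon. For the measured compounds named here, since none of the measured compounds separates itself from the scatter, this change offers no grounds for expecting movement, and the expected step of no change at the digits printed from compound 3 to compound 4 (within the scatter) is none beyond the scatter. Compound 4 is therefore estimated at 3% in this assay, with a range from 0% to 12%.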

Compound 4, a percentage reported as inhibition, at one concentration (the size of the read-out at that concentration, not a potency): 1%
Estimate against measurement, compound 4: 2 percentage points above; low and high end bracket the measured number.
By their numbers in this assay, from the lowest: compounds 1, 4, 2 and 3 (each within the scatter of the next).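

In this assay, the single-place change gives a number 2 percentage points lower from compound 3 to compound 4 (within the scatter). For the compounds shown here, removing the 2,5-difluorophenyl group with its six-membered aromatic ring from this aromatic carbon next to the ring sulfur, and putting bromo there, therefore does not separate the two compounds on this read-out, a finding the earlier compounds could not supply without a single-place pair. No measurement at hand speaks to why the two compounds read alike.

As far as these compounds go, whether an amine, a carboxylic acid or a longer carbon chain at this position would take the read-out beyond the scatter remains open. Also open, from the compounds shown here alone, is whether the same exchange of bromo for 2,5-difluorophenyl would matter on a compound with clear inhibition at the one concentration tested.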